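A few compounds are considered here, and "the series" means these few. Any claim that something is new, unique, unknown or untested is made for them only; others in the source may bear on it.

Three compounds of the series have been run in an ADME assay on J774 cells (Mus musculus, strain BALB/c) for cytotoxicity, read by resazurin assay, with a stated time of 72 h; a lower number here means that less compound is tolerated, a higher number that more compound is tolerated. Compound 1 `CC(/C=N/Nc1ccc([N+](=O)[O-])cc1)=N\NC(=O)c1ccccc1O` gives 29500 nM in this assay. Compound 2 `COc1cc(C(=O)N/N=C(C)/C=N/Nc2ccc([N+](=O)[O-])cc2)ccc1O` reaches only the limit of this assay, at > 100000 nM. Compound 3 `COc1ccc(C(=O)N/N=C(C)/C=N/Nc2ccc([N+](=O)[O-])cc2)cc1` likewise stands at a limit, > 100000 nM, so for compound 3 only a floor is known in this assay. The change at the carbonyl carbon gave an at least 3.3-fold higher number from compound 1 to compound 2 (0.53 log units; beyond the scatter) and an at least 3.3-fold higher number from compound 1 to compound 3 (0.53 log units; beyond the scatter), both beyond the scatter; the pair compound 2 and compound 3 gives a step that the two limits leave unreadable from compound 2 to compound 3, since both sit at the limit of > 100000 nM in this assay, at which 2 of the 3 values shown sit.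

Compound 4 `CC(/C=N/Nc1ccc([N+](=O)[O-])cc1)=N\NC(=O)c1ccccc1I` differs from compound 3 by 2-iodophenyl in place of 4-methoxyphenyl on a carbonyl carbon. For the measured compounds named here, the step bearing on it is the one from compound 1 to compound 3, where the 4-methoxyphenyl group went with a number beyond the limit; its removal leaves a downward step possible, while the starting point at a limit keeps its size unreadable. For compound 4 a value of 60000 nM is expected in this assay, between 25000 nM and 150000 nM. The expected step is therefore an at least 1.6-fold lower number from compound 3 to compound 4 (0.22 log units; that floor lies within the scatter), with a fair chance that only a limit is again reported.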

Compound 4, half-maximal cytotoxic concentration: 40000 nM
Compound 4: the middle estimate sits 1.5-fold (0.18 log units) above what was measured, within the range that was stated.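

In this assay, 2-iodophenyl on the carbonyl carbon gives an at least 2.5-fold lower number from compound 3 to compound 4 (0.39 log units; beyond the scatter) and an at least 2.5-fold lower number from compound 2 to compound 4 (0.39 log units; beyond the scatter), so the drop from the limit seen with 2-hydroxyphenyl in compound 1 also appears with a group that carries no hydrogen-bond donor. With iodo in place of hydroxy on an aromatic carbon, the result is a 1.4-fold higher number from compound 1 to compound 4 (0.13 log units; within the scatter), so the hydroxy group is not needed for a readable value, and the two groups are not told apart here. The steps from compound 2 and compound 3 give only floors, as both compounds stand at a limit: the limit of > 100000 nM in this assay, at which 2 of the 4 values shown sit.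

From the compounds shown here alone, how far compound 2 and compound 3 lie beyond that limit stays unknown. Also open, going by these compounds, is whether 2-aminophenyl or 2-carboxyphenyl on the carbonyl carbon would fall with compound 1 and compound 4 or reach the limit.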